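Moving the Methyl on the Phenyl Attached to Nitrogen

The source may report more compounds than this note shows. Statements on the series, on what has been measured and on what is new or still open speak of the compounds shown alone.

Four compounds share one core and differ only in the groups on their two outer rings. Compound 1 `Cc1nc(Nc2ccc(Cl)cc2)sc1C(=O)/C=C/c1ccccc1` in a functional assay on PC-3 cells (Homo sapiens) for cytotoxicity, read by MTT assay (on this read-out lower numbers stand for stronger inhibition and higher numbers for weaker inhibition), gives 24600 nM. Compound 2 `Cc1cccc(Nc2nc(C)c(C(=O)/C=C/c3ccccc3Cl)s2)c1` gives 22200 nM in this assay. Compound 3 `Cc1ccccc1Nc1nc(C)c(C(=O)/C=C/c2ccccc2)s1` reaches only the limit of this assay, > 25000 nM, so for it only a bound and no number is known (the limit of > 25000 nM in this assay, at which 1 of the 3 values shown sits). For the measured compounds named here, the one measured step that touches compound 3, an at least 1.0-fold higher number from compound 1 to compound 3 (0.00 log units; that floor lies within the scatter), sits within the scatter.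

Compound 4 `Cc1cccc(Nc2nc(C)c(C(=O)/C=C/c3ccccc3)s2)c1` differs from compound 3 by 3-methylphenyl in place of 2-methylphenyl on a nitrogen on an aromatic ring. Going by the values given here, no measured step covers this exact change; compound 2 carries the same 3-methylphenyl group together with another difference, and its value lies close to that of compound 1. All three measured values sit near the top of the range of this assay, so the step that the limit leaves unreadable from compound 3 to compound 4 is expected to be none beyond the scatter. Compound 4 is therefore estimated at 26000 nM, between 14000 nM and 50000 nM, with a real chance that only a limit is reported again.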

Compound 4, half-maximal inhibitory concentration: 11700 nM
Compound 4: middle estimate off by 2.2-fold (0.35 log units), on the high side; measured number below the stated range.
By their numbers in this assay, from the lowest: compounds 4, 2 and 1 (each within the scatter of the next, the first and the last beyond it). At a limit, above all of these: compound 3.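

Moving the methyl matters at this position. With 3-methylphenyl in place of 2-methylphenyl on a nitrogen on an aromatic ring, this assay shows an at least 2.1-fold lower number from compound 3 to compound 4 (0.32 log units; beyond the scatter), so the same atoms, joined differently, are enough to give a number rather than a limit. That size is only a floor, as compound 3 stands at a limit and has no number: the limit of > 25000 nM in this assay, at which 1 of the 4 values shown sits. The other comparisons show a 2.1-fold lower number from compound 1 to compound 4 (0.32 log units; beyond the scatter), a modest step, and, with hydrogen in place of chloro on an aromatic carbon, a 1.9-fold lower number from compound 2 to compound 4 (0.28 log units; within the scatter), so that chloro makes no readable difference here.

From the compounds shown here alone, what stays open is whether an ethyl or a methoxy group in place of this methyl would change the number further. Going by these compounds, it is also open whether an amine there would do so.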